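Trading One Side Group on a Shared Core

A few compounds are considered here, and "the series" means these few. Any claim that something is new, unique, unknown or untested is made for them only; others in the source may bear on it.

In a functional assay on A549 cells (Homo sapiens) for antiproliferative activity, read by MTT assay, with a stated time of 48 h (a higher number here means a weaker inhibitor, a lower number a stronger inhibitor), compound 1 (`CC(C)=CCC[C@]1(C)/C=C/[C@@H](OC(=O)C=C(C)C)[C@](C)(O)/C=C/C(=O)/C(Cn2cc(CO)nn2)=C\C1`) gives 3470 nM and compound 2 (`CO/N=C/C1=C/C[C@](C)(CCC=C(C)C)/C=C/[C@@H](OC(=O)C=C(C)C)[C@](C)(O)/C=C/C1=O`) gives 3470 nM, so compound 2 stands level with compound 1. The next structure, compound 3 (`CC(C)=CCC[C@]1(C)/C=C/[C@@H](OC(=O)C=C(C)C)[C@](C)(O)/C=C/C(=O)/C(C(=O)N(C)C)=C\C1`), keeps the shared core and changes only the group that compound 2 carries on a double-bonded ring carbon. That group gives way to dimethylcarbamoyl: a group of 5 heavy atoms (3 carbon, 1 nitrogen, 1 oxygen; no ring) in place of a group of 4 heavy atoms (2 carbon, 1 nitrogen, 1 oxygen; no ring), on a double-bonded ring carbon.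

Among the measured compounds shown here, only one measured step bears on this change. It concerns the same ring carbon, where a much larger group containing a five-membered aromatic ring was exchanged for the group found in compound 2, and the result was no change at the digits printed from compound 1 to compound 2 (within the scatter). Two quite different groups at this carbon therefore gave the same reading, which suggests that a further exchange may matter little. This is thin evidence, since no amide at this carbon has yet been measured.

The expected result in this assay is a 1.0-fold higher number from compound 2 to compound 3 (0.00 log units; within the scatter), with no step beyond the scatter foreseen. The estimate for compound 3 is 3500 nM, with an expected range of 1400 nM to 9000 nM.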

Compound 3, half-maximal inhibitory concentration: 2700 nM
Beside the measured number, compound 3's estimate is 1.3-fold (0.11 log units) above it, and the stated range covers the measured number.
By their numbers in this assay, from the lowest: compounds 3, 1 and 2 (each within the scatter of the next).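

In this assay dimethylcarbamoyl joins the two earlier groups on this double-bonded ring carbon, and the readings give a 1.3-fold lower number from compound 2 to compound 3 (0.11 log units; within the scatter) and a 1.3-fold lower number from compound 1 to compound 3 (0.11 log units; within the scatter). Until now, one exchange at this place had shown no step beyond the scatter; compound 3 adds a third group to that picture, so the three groups compared here, one carrying a five-membered aromatic ring and two with no ring, all read alike in this cell test. The change from compound 2 to compound 3 also takes the count of hydrogen-bond acceptors in the group from two to one with no step beyond the scatter, though no supporting measurement explains why these different groups give such similar readings.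

The compounds shown leave open whether a carboxylic acid, a primary amine or a longer carbon chain on this ring carbon would also stay level with compounds 1, 2 and 3 or would produce a step beyond the scatter. They also leave open whether the same agreement among these three groups would hold in a different cell line.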